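Fluoro for Hydrogen on the Phenylcarbamoyl Ring

This account rests on a few compounds, and the source may have more. Where it says the series, first, only, none or still open, it means among the compounds named here.

Compound 1 `CC1=C(/C=C/C(C)=C/C=C/C(C)=C\C(=O)Nc2ccccc2)C(C)(C)CC=C1c1cccnc1`: 39800 nM
Compound 2 `CC1=C(/C=C/C(C)=C/C=C/C(C)=C\C(=O)Nc2ccccc2)C(C)(C)CCC1n1ccnc1`: 2540 nM

In a functional assay on MDA-MB-468 cells (Homo sapiens) for inhibition, read by MTT assay (a higher number here means a weaker inhibitor of growth, a lower number a stronger inhibitor of growth), compound 1 gives 39800 nM, while compound 2 gives 2540 nM. Of these two numbers compound 2 has the lowest, and the gap to compound 1 lies well beyond the scatter of repeated measurements. Compound 3 `CC1=C(/C=C/C(C)=C/C=C/C(C)=C\C(=O)Nc2cccc(F)c2)C(C)(C)CCC1n1ccnc1` has not yet been measured. It differs from compound 2 in one place: fluoro in place of hydrogen on an aromatic carbon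

Among the measured compounds shown here, no pair of measured compounds shows this kind of change, so nothing here tells its direction. A step of a 1.2-fold lower number from compound 2 to compound 3 (0.06 log units; within the scatter) is expected, lying within the scatter. Compound 3 is estimated at 2200 nM, with a range from 800 nM to 6000 nM.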

Compound 3, concentration for 50% growth inhibition: 6760 nM
For compound 3 the middle estimate is 3.1-fold (0.49 log units) below the measured one; the whole stated range lies below it.
By their numbers in this assay, from the lowest: compound 2; then compound 3; then compound 1.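

Swapping hydrogen for fluoro on the phenylcarbamoyl ring is not a silent change in this assay, since it gives a 2.7-fold higher number from compound 2 to compound 3 (0.43 log units; beyond the scatter) and so a weaker inhibitor of growth. This position therefore responds to a single added atom, at least on the core of compound 2. No measurement here accounts for the loss. Still open, as far as these compounds go, is how a larger group at this position, such as methoxy or an amine, would behave, and whether fluoro elsewhere on this ring would also raise the number.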